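Moving from 3-nitrobenzyl to 4-methylbenzyl on sulfur

The source may report more compounds than this note shows. Statements on the series, on what has been measured and on what is new or still open speak of the compounds shown alone.

Measured so far in a functional assay on BGC-823 cells (Homo sapiens) for antiproliferative activity, read by MTT assay, with a stated time of 24 h; a higher number here means a weaker inhibitor, a lower number a stronger inhibitor
- compound 1 `Sc1nnc(-c2ccc3c(c2)OCCO3)n1-c1ccccc1` gives 47000 nM
- compound 2 `O=[N+]([O-])c1cccc(CSc2nnc(-c3ccc4c(c3)OCCO4)n2-c2ccccc2)c1` gives 30100 nM

Compound 2 stands level with compound 1 within the scatter (a 1.6-fold lower number from compound 1 to compound 2 (0.19 log units; within the scatter)). Compound 3 `Cc1ccc(CSc2nnc(-c3ccc4c(c3)OCCO4)n2-c2ccccc2)cc1` departs from compound 2 in one place (4-methylphenyl in place of 3-nitrophenyl on a saturated chain carbon bound to a sulfur), with 4-methylphenyl in place of 3-nitrophenyl on a saturated chain carbon bound to a sulfur. Going by the values given here, only one measured step bears on this change, the placing of 3-nitrobenzyl on the sulfur of compound 1 to give compound 2 (a 1.6-fold lower number from compound 1 to compound 2 (0.19 log units; within the scatter)), and it stayed within the scatter. Among the compounds with values here, no measured pair varies the group on the benzyl carbon, so the support is thin. No step beyond the scatter is therefore expected in this assay. The expected step is small (a 1.1-fold higher number from compound 2 to compound 3 (0.03 log units; within the scatter)). Compound 3 is estimated at 32000 nM, with an expected range from 14000 nM to 70000 nM.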

Compound 3, half-maximal inhibitory concentration: 44300 nM
For compound 3 the middle estimate is 1.4-fold (0.14 log units) below the measured one, and the stated range covers the measured number.
By their numbers in this assay, from the lowest: compounds 2, 3 and 1 (each within the scatter of the next).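

In this assay, going by these compounds alone, the first measured change of the group on the saturated chain carbon bound to a sulfur gives a 1.5-fold higher number from compound 2 to compound 3 (0.17 log units; within the scatter), so losing the 3-nitrophenyl group with its 2 hydrogen-bond acceptors for the all-carbon 4-methylphenyl group does not move the number beyond the scatter. A second benzyl group on the sulfur gives a 1.1-fold lower number from compound 1 to compound 3 (0.03 log units; within the scatter), so neither benzyl group shown separates from the parent compound with hydrogen on the sulfur. No evidence on the cause of this flat behaviour is at hand.

Compound 2 and compound 3 differ in both the substituent and its ring position, so these two changes remain unseparated. On these data alone, it remains open whether a different kind of group on the sulfur, such as an amine or a carboxylic acid on a longer chain, would produce a step beyond the scatter.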